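Swapping the Amide Partner: A Cytotoxicity Step to Compound 4

The compounds below may be only part of what the source reports. "The series", "measured", "known", "first", "only" and "open" are said of these compounds alone.

Three compounds built on one shared core, carrying an amino group, a trifluoromethyl group and a phenyl group, differ only in the amide attached through a methylene to the core. In a functional assay on HeLa cells (Homo sapiens) for cytotoxicity, read by MTT assay, with a stated time of 24 h (on this read-out higher numbers stand for weaker inhibition and lower numbers for stronger inhibition), compound 1 `CNC(=O)Cn1nc(N)c2c(C(F)(F)F)cc(-c3ccccc3)nc21` gives 12200 nM. In this assay compound 2 `CCCNC(=O)Cn1nc(N)c2c(C(F)(F)F)cc(-c3ccccc3)nc21` gives 15900 nM. In this assay compound 3 `Nc1nn(CC(=O)N2CCOCC2)c2nc(-c3ccccc3)cc(C(F)(F)F)c12` gives 6600 nM, the lowest of the three numbers, although its gap to compound 1 lies within the scatter, while a 2.4-fold lower number from compound 2 to compound 3 (0.38 log units; beyond the scatter).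

Compound 4 `Nc1nn(CC(=O)NCC(=O)O)c2nc(-c3ccccc3)cc(C(F)(F)F)c12` is compound 3 with one change: (carboxymethyl)amino in place of morpholin-4-yl on a carbonyl carbon. The measured steps that bear on this change are those that alter the same amide partner: a 1.3-fold higher number from compound 1 to compound 2 (0.12 log units; within the scatter), a 1.8-fold lower number from compound 1 to compound 3 (0.27 log units; within the scatter) and a 2.4-fold lower number from compound 2 to compound 3 (0.38 log units; beyond the scatter). All three are small and the widest is only modest. A further change at this place is therefore expected to give a similarly small step, with no clear direction. Compound 4 again carries an amide hydrogen, as do compound 1 at 12200 nM and compound 2 at 15900 nM, so its number is expected to sit near theirs. Compound 4 is thus estimated at 12000 nM, within a range from 5000 nM to 30000 nM. This expectation amounts to a 1.8-fold higher number from compound 3 to compound 4 (0.26 log units; within the scatter).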

Compound 4, half-maximal inhibitory concentration: 19100 nM
Estimate against measurement, compound 4: 1.6-fold (0.20 log units) below; the range from low to high includes it.
By their numbers in this assay, from the lowest: compounds 3, 1, 2 and 4 (each within the scatter of the next, the first and the last beyond it).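

In this assay the change to (carboxymethyl)amino gives a 2.9-fold higher number from compound 3 to compound 4 (0.46 log units; beyond the scatter) and so sets compound 3 apart from a second compound, although compound 3 still lies within the scatter of compound 1. A carboxy group on the saturated chain carbon bound to the amide-type nitrogen makes little difference here: it gives a 1.2-fold higher number from compound 2 to compound 4 (0.08 log units; within the scatter) in place of ethyl and a 1.6-fold higher number from compound 1 to compound 4 (0.19 log units; within the scatter) in place of hydrogen, so this read-out cannot separate compound 1, compound 2 and compound 4. The three partners that keep the amide hydrogen therefore fall together, while compound 3, which lacks it, has the lowest number, but compound 1 blurs this split through its small gap to compound 3.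

What lies behind the step from compound 3 to compound 4 stays open, with no measurement at hand that explains it. Also open, going by these compounds, is whether the methyl ester of compound 4 would stay with this group, and whether piperidin-1-yl or dimethylamino on the carbonyl carbon would match morpholin-4-yl.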